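From a trifluorophenyl ring to a dihydropyranyl ring in solubility

The source may report more compounds than this note shows. Statements on the series, on what has been measured and on what is new or still open speak of the compounds shown alone.

Compound 3 `Cc1cc(NCc2ccccn2)n2ncc(-c3cc(F)c(F)c(F)c3)c2n1` stands at a limit in a physicochemical assay for solubility, read by HPLC, using the shake flask method, measured as kinetic solubility, with a stated time of 2 h, at pH 7.4; on this read-out lower numbers stand for lower solubility and higher numbers for higher solubility: its value of < 5000 nM is a limit of the assay and not a number. Compound 1 `Cc1cc(NCc2ccccn2)n2ncc(-c3ccc(N(C)C)cc3)c2n1` likewise gives only a limit, < 5000 nM. Compound 2 `Cc1cc(NCc2ccccn2)n2ncc(-c3ccccc3F)c2n1` gives 5000 nM. Compound 4 `Cc1cc(NCc2ccccn2)n2ncc(C3=CCOCC3)c2n1` is not yet measured; it differs from compound 3 by a group of 6 heavy atoms (5 carbon, 1 oxygen; one six-membered non-aromatic ring with 1 hetero atom) in place of a group of 9 heavy atoms (6 carbon, 3 fluorine; one six-membered aromatic ring of carbon only), on an aromatic carbon. For the measured compounds named here, none of the measured steps exchanges an aromatic ring for a non-aromatic one; the steps that touch the same position are a step that the two limits leave unreadable from compound 1 to compound 3 and a number no higher from compound 2 to compound 3 (the limit leaves the size open), both of unreadable size because of the limit of < 5000 nM in this assay, at which 2 of the 3 values shown sit. The measured steps therefore set no size for what is expected. Compound 4 is estimated at 12000 nM, within a range from 3000 nM to 50000 nM. That estimate means an expected step of an at least 2.4-fold higher number from compound 3 to compound 4 (0.38 log units; beyond the scatter).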

Compound 4, solubility: 171000 nM
Compound 4: middle estimate off by 14-fold (1.15 log units), on the low side; measured number above the stated range.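

At this position, on an aromatic carbon of the five-membered aromatic ring, exchanging an aromatic ring for a non-aromatic one gives a readable result in this assay: it yields a 34-fold higher number from compound 2 to compound 4 (1.53 log units; beyond the scatter) and an at least 34-fold higher number from compound 3 to compound 4 (1.53 log units; beyond the scatter) and also an at least 34-fold higher number from compound 1 to compound 4 (1.53 log units; beyond the scatter) in a single change of group. The steps among the three phenyl-bearing compounds cannot be read, and those starting from compound 1 and compound 3 set only a lower bound on the size, because their starting values are limits: the limit of < 5000 nM in this assay, at which 2 of the 4 values shown sit.

The compounds shown leave open whether the ring oxygen, the double bond or the loss of the aromatic ring carries the step. A cyclohexenyl ring of carbon only, a saturated tetrahydropyranyl ring or a piperidine ring at this place would separate these.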